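Taking the amino group off compound 1

The compounds below may be only part of what the source reports. "The series", "measured", "known", "first", "only" and "open" are said of these compounds alone.

In a functional assay on the whole organism with Mus musculus as the target (on this read-out lower numbers stand for an effect already at smaller amounts and higher numbers for an effect only at larger amounts of compound), compound 1 (`COc1cc2c(cc1OC)C(c1ccc(N)cc1)=NN=C(S)C2`) gives 15.4 umol/kg. Compound 3 (`COc1cc2c(cc1OC)C(c1ccc(N)cc1)=NNC(=O)C2`) gives 22.6 umol/kg, which lies within the scatter of compound 1, so the two cannot be ranked against each other. Compound 2 (`COc1cc2c(cc1OC)C(c1ccccc1)=NNC(=O)C2`) gives 68.2 umol/kg, and this number stands clearly above those of both compound 1 and compound 3. Compound 1 therefore shares the low end of the three numbers with compound 3.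

The open case is compound 4 (`COc1cc2c(cc1OC)C(c1ccccc1)=NN=C(S)C2`), which has hydrogen in place of amino on an aromatic carbon. For the measured compounds named here, only one measured step bears on this change, a 3.0-fold lower number from compound 2 to compound 3 (0.48 log units; beyond the scatter). That step is modest and beyond the scatter, and it runs in the opposite direction, with amino in place of hydrogen. Going by the values given here, it also belongs to a pair whose core differs from that of compound 1, and no pair on the core of compound 1 has yet been measured, so carrying it over is an assumption. If it holds, the number in this assay should rise by a similar amount, giving an expected 2.9-fold higher number from compound 1 to compound 4 (0.47 log units; beyond the scatter). For compound 4 the estimate is 45 umol/kg, with an expected range from 20 umol/kg to 100 umol/kg.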

Compound 4, dose for half-maximal effect: 33.7 umol/kg
Estimate against measurement, compound 4: 1.3-fold (0.13 log units) above; low and high end bracket the measured number.
By their numbers in this assay, from the lowest: compounds 1, 3 and 4 (each within the scatter of the next, the first and the last beyond it); then compound 2.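

On a second core, the change from 4-aminophenyl to phenyl gives a 2.2-fold higher number from compound 1 to compound 4 (0.34 log units; beyond the scatter) in this assay. For the compounds shown here, this position therefore no longer rests on a single measured pair, as it did when the only step came from compound 2 and compound 3, which share a different core. The change now runs the same way on both cores, and the two steps agree in size: the same change on two cores in this assay, a 3.0-fold lower number (0.48 log units; beyond the scatter) from compound 2 to compound 3 and a 2.2-fold lower number (0.34 log units; beyond the scatter) from compound 4 to compound 1, 1.4-fold (0.14 log units) apart, within the scatter of two such steps

These two pairs compare only amino with hydrogen at this place on the aromatic ring, so the compounds shown leave open how a hydroxyl group, a methoxy group, an acetamide or a carboxylic acid would read there. They also leave open whether a methylamino or dimethylamino group would keep the lower number that amino gives on both cores, and whether the agreement between the two cores would extend to any further core.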